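The source may report more compounds than this note shows. Statements on the series, on what has been measured and on what is new or still open speak of the compounds shown alone.

Measured in a functional assay on LNCaP cells (Homo sapiens) for antiproliferative activity; on this read-out higher numbers stand for weaker inhibition and lower numbers for stronger inhibition:
- Compound 1 `CNC(=O)C[C@@H]1C[C@@H](c2ccc(Cl)c(Cl)c2)[C@H](NC(=O)c2cc(-c3c(Cl)cnn3C)c(Cl)o2)CN1`: 40 nM
- Compound 2 `CC(=O)NCC[C@@H]1C[C@@H](c2ccc(F)c(F)c2)[C@H](NC(=O)c2cc(-c3c(Cl)cnn3C)c(Cl)o2)CN1`: 130 nM
- Compound 3 `Cn1ncc(Cl)c1-c1cc(C(=O)N[C@@H]2CN[C@H](CC(N)=O)C[C@H]2c2ccc(Cl)c(Cl)c2)oc1Cl`: 160 nM

The number of compound 3 cannot be told apart from that of compound 2, and only compound 1 gives a clearly lower one. Compound 4 `Cn1ncc(Cl)c1-c1cc(C(=O)N[C@@H]2CN[C@H](CC(=O)NC3CC3)C[C@H]2c2ccc(Cl)c(Cl)c2)oc1Cl` differs from compound 3 by one change: cyclopropyl in place of hydrogen on an amide-type nitrogen. That puts cyclopropyl in place of hydrogen on an amide-type nitrogen. Among the compounds with values here, one measured step touches this nitrogen: a 4.0-fold higher number from compound 1 to compound 3 (0.60 log units; beyond the scatter). Read backwards, it shows that methyl in place of hydrogen there goes with a lower number. It is a single, modest step, and methyl is not cyclopropyl, so a drop of similar size is only a tentative expectation. The expected step is a 2.7-fold lower number from compound 3 to compound 4 (0.43 log units; beyond the scatter). The estimated value for compound 4 is 60 nM, within an expected range of 20 nM to 180 nM.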

Compound 4, half-maximal inhibitory concentration: 190 nM
Beside the measured number, compound 4's estimate is 3.2-fold (0.50 log units) below it, and the stated range ends below it.
By their numbers in this assay, from the lowest: compound 1; then compounds 2, 3 and 4 (each within the scatter of the next).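

In this assay, cyclopropyl in place of hydrogen on this amide nitrogen gives a 1.2-fold higher number from compound 3 to compound 4 (0.07 log units; within the scatter), so the lower number seen with methyl does not extend to this larger group. Cyclopropyl in place of methyl gives a 4.8-fold higher number from compound 1 to compound 4 (0.68 log units; beyond the scatter), which leaves methyl as the only one of the three groups that stands apart at this position. Nothing available explains this difference.

As far as these compounds go, whether the lower number belongs to methyl alone stays open. Ethyl or a longer chain on the same nitrogen could show how narrow the preference is.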